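This account rests on a few compounds, and the source may have more. Where it says the series, first, only, none or still open, it means among the compounds named here.

In an ADME assay on L6 cells (Rattus norvegicus) for cytotoxicity, read by resazurin assay; a higher number here means a weaker inhibitor, a lower number a stronger inhibitor:
- Compound 1 `COc1cc(OC)cc(-c2nc3ccc(-c4nc5cc(C(=N)N)ccc5[nH]4)cc3[nH]2)c1`: 25.5 ug/mL
- Compound 2 `COc1ccc(-c2nc3ccc(-c4nc5cc(C(=N)N)ccc5[nH]4)cc3[nH]2)cc1OC`: > 90 ug/mL

For compound 2, > 90 ug/mL is a limit of this assay and not a number. Compound 3 `COc1cc(-c2nc3ccc(-c4nc5cc(C(=N)N)ccc5[nH]4)cc3[nH]2)ccc1OCc1ccccc1` differs from compound 2 by phenyl in place of hydrogen on a saturated chain carbon bound to an oxygen on an aromatic ring, which turns one methoxy into benzyloxy. Among the compounds with values here, only one measured step bears on this, and only loosely: 3,4-dimethoxyphenyl in place of 3,5-dimethoxyphenyl gave an at least 3.5-fold higher number from compound 1 to compound 2 (0.54 log units; beyond the scatter). That step shows that changes on this aromatic ring can move the number beyond the scatter, so a modest move towards a lower number is expected, with its size uncertain. The expected step is an at least 2.0-fold lower number from compound 2 to compound 3 (0.30 log units; that floor lies within the scatter). Compound 3 is estimated at 45 ug/mL, with an expected range of 12 ug/mL to 110 ug/mL.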

Compound 3, half-maximal inhibitory concentration: 19.8 ug/mL
The estimate for compound 3 lay 2.3-fold (0.36 log units) above the measured number, within the range that was stated.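

In this assay, turning methoxy into benzyloxy gave an at least 4.5-fold lower number from compound 2 to compound 3 (0.65 log units; beyond the scatter). This shows that the group on this oxygen, and not only the arrangement of the two methoxy groups on the ring, can move the number beyond the scatter. The step starts from a limit of the assay and not a number, so its printed size is only a floor, for compound 2: the limit of > 90 ug/mL in this assay, at which 1 of the 3 values shown sits.

As far as these compounds go, whether an ethyl group or a longer chain on this oxygen would lower the number as benzyl does, or whether the phenyl ring is needed, stays open. So does the effect of an amine on that phenyl ring.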